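Phenyl to 2,6-dibromophenyl on the shared core

This account rests on a few compounds, and the source may have more. Where it says the series, first, only, none or still open, it means among the compounds named here.

In an ADME assay on Huh-7 cells (Homo sapiens) for cytotoxicity, read by MTT assay, with a stated time of 4 h, at 37 degrees C (on this read-out lower numbers stand for higher toxicity in this test and higher numbers for lower toxicity in this test), compound 2 `Nc1nc(Nc2ccccc2)nc2[nH]c(=O)c(-c3ccccc3)cc12` gives 13800 nM, the higher of the two numbers available and therefore the lower toxicity in this test. For the measured compounds named here, the only other measured compound, compound 1 `Nc1nc(Nc2ccccc2)nc2[nH]c(=O)c(-c3c(F)cccc3F)cc12`, gives 2400 nM. Compound 3 `Nc1nc(Nc2ccccc2)nc2[nH]c(=O)c(-c3c(Br)cccc3Br)cc12` has not yet been measured. Its structure departs from that of compound 2 by one change: 2,6-dibromophenyl in place of phenyl on an aromatic carbon. In words, 2,6-dibromophenyl stands in place of phenyl on an aromatic carbon.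

Going by the values given here, one measured step bears on this change. It is a 5.8-fold higher number from compound 1 to compound 2 (0.76 log units; beyond the scatter), a modest step beyond the scatter, with phenyl in place of 2,6-difluorophenyl on an aromatic carbon. Read in reverse, this single pair shows a 2,6-dihalogenated phenyl going with the lower number, but it involves fluorine, and no bromine compound has been measured. A step of similar size towards a lower number in this assay is therefore expected, with wide uncertainty. The expected change is a 5.5-fold lower number from compound 2 to compound 3 (0.74 log units; beyond the scatter). The estimate for compound 3 is 2500 nM, with an expected range from 700 nM to 9000 nM.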

Compound 3, half-maximal cytotoxic concentration: 166000 nM
The estimate for compound 3 lay 66-fold (1.82 log units) below the measured number, outside the stated range (above it).
By their numbers in this assay, from the lowest: compound 1; then compound 2; then compound 3.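

The new result reverses the direction seen with fluorine: in this assay, placing 2,6-dibromophenyl on this aromatic carbon gives a 12-fold higher number from compound 2 to compound 3 (1.08 log units; beyond the scatter) and so lower toxicity in this test, whereas 2,6-difluorophenyl goes with the lower number in the step of a 5.8-fold higher number from compound 1 to compound 2 (0.76 log units; beyond the scatter) on the same core. Exchanging one halogen for the other at this place gives the widest gap in the set, a 69-fold higher number from compound 1 to compound 3 (1.84 log units; beyond the scatter) and compound 2, with its unsubstituted phenyl, falls between the two dihalogenated compounds, so among these three compounds, having two halogens on the phenyl does not by itself set the direction of the change. Nothing available explains why fluorine and bromine part ways here.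

The compounds shown leave open where 2,6-dichlorophenyl or 2,6-dimethylphenyl would fall in this order, and whether a phenyl carrying a single bromine would go with compound 3 or stay closer to compound 2. They also leave open whether the same order would hold with a methoxy group on the other phenyl ring of the shared core.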